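The compounds below may be only part of what the source reports. "The series", "measured", "known", "first", "only" and "open" are said of these compounds alone.

Measured compounds:
Compound 1, `C=C1[C@@H](OC(C)=O)C[C@@H]2[C@](C)(CO[Si](C)(C)C(C)(C)C)[C@H](OC(C)=O)CC[C@@]2(C)[C@@H]1C[C@@H](Nc1ccc(OC)cc1)C1=CCOC1=O`: 4280 nM in a functional assay on MCF7 cells (Homo sapiens) for cytotoxicity, read by sulforhodamine B assay; a lower number here means a stronger inhibitor, a higher number a weaker inhibitor.
Compound 2, `C=C1[C@@H](OC(C)=O)C[C@@H]2[C@](C)(COC=O)[C@H](OC(C)=O)CC[C@@]2(C)[C@@H]1C[C@@H](Nc1ccc(OC)c(OC)c1)C1=CCOC1=O`: only a limit, > 50000 nM, in this assay.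
Compound 3, `C=C1CC[C@@H]2[C@](C)(CO[Si](C)(C)C(C)(C)C)[C@H](OC(C)=O)CC[C@@]2(C)[C@@H]1C/C=C1/C(=O)OC[C@H]1OC(C)=O`: 4840 nM in this assay.

Compound 2 stands at the far end of these numbers, where (the limit of > 50000 nM in this assay, at which 1 of the 3 values shown sits); no number for it is known, only that limit. For the measured compounds named here, no two of the measured compounds differ in a single place, so no measured step is available to lean on. Compound 4 is `C=C1[C@@H](OC(C)=O)C[C@@H]2[C@](C)(COC=O)[C@H](OC(C)=O)CC[C@@]2(C)[C@@H]1C[C@@H](Nc1ccc(C(=O)O)cc1)C1=CCOC1=O`, and its change from compound 2 is 4-carboxyphenyl in place of 3,4-dimethoxyphenyl on an amine nitrogen. Since compound 2 gave only a limit in this assay, the step of an at least 1.1-fold lower number from compound 2 to compound 4 (0.04 log units; that floor lies within the scatter) is expected to be no larger than the usual scatter, with a fair chance that compound 4 also ends at a limit. Compound 4 is estimated at 45000 nM, within 15000 nM to 120000 nM.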

Compound 4, half-maximal inhibitory concentration: 41700 nM
Estimate against measurement, compound 4: 1.1-fold (0.03 log units) above, within the range that was stated.
By their numbers in this assay, from the lowest: compounds 1 and 3 (each within the scatter of the next); then compound 4. At a limit, above all of these: compound 2.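

In this assay, 4-carboxyphenyl in place of 3,4-dimethoxyphenyl on an amine nitrogen gives an at least 1.1-fold lower number from compound 2 to compound 4 (0.07 log units; that floor lies within the scatter). With this group, the core of compound 2 now has a real number at this position: compound 4 reads 41700 nM. The true size of the step stays unknown, and it may be larger, because one end of it is not a number: the limit of > 50000 nM in this assay, at which 1 of the 4 values shown sits.

The compounds shown leave open what a plain phenyl or the methyl ester of this acid would read on the same core. Whether the carboxylic acid itself matters at this position therefore remains unanswered.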